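Trading a Saturated Ring for an Aromatic One

This account rests on a few compounds, and the source may have more. Where it says the series, first, only, none or still open, it means among the compounds named here.

Of the compounds shown here, three sharing one core have been tested in an assay on isolated protein for binding affinity to B1 bradykinin receptor (Homo sapiens); on this read-out higher numbers stand for weaker inhibition and lower numbers for stronger inhibition. Compound 1 `COC(=O)c1ccccc1N1CCC(C)(CNc2nccc(C)c2NC(=O)CC#N)CC1` gives 3500 nM in this assay. Compound 2 `COC(=O)C1CCCN1c1ccc(CNc2nccc(C)c2NC(=O)CC#N)cc1` reaches only the limit of this assay, > 5000 nM (the limit of > 5000 nM in this assay, at which 1 of the 3 values shown sits). Compound 3 `COC(=O)C1CCCCC1c1ccc(CNc2nccc(C)c2NC(=O)CC#N)cc1` gives 2.2 nM in this assay, the lowest of the two numbers shown and far below compound 1.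

One single-point step has been measured: swapping the ring-bearing group gave an at least 2200-fold lower number from compound 2 to compound 3 (3.35 log units; beyond the scatter), a change from a limit to a firm number.

Compound 4 `COC(=O)c1ccccc1-c1ccc(CNc2nccc(C)c2NC(=O)CC#N)cc1` is not yet measured. It differs from compound 3 in one place: 2-(methoxycarbonyl)phenyl in place of 2-(methoxycarbonyl)cyclohexyl on an aromatic carbon. The measured step does not mirror this change, since it exchanged 2-(methoxycarbonyl)pyrrolidin-1-yl for 2-(methoxycarbonyl)cyclohexyl rather than a non-aromatic six-membered ring for an aromatic one. What it does show is that this position tolerates large shifts in this assay.

The methoxycarbonyl group and its position are kept, so compound 4 is expected to stay close to compound 3, with a modest move estimated at a 4.5-fold higher number from compound 3 to compound 4 (0.66 log units; beyond the scatter). Compound 4 is therefore expected to give about 10 nM, within a range from 2 nM to 60 nM.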

Compound 4, inhibition constant in the B1 bradykinin receptor assay: 11 nM
Compound 4: the middle estimate sits 1.1-fold (0.04 log units) below what was measured; the measured number falls inside the stated range.
By their numbers in the B1 bradykinin receptor assay, from the lowest: compound 3; then compound 4; then compound 1. At a limit, above all of these: compound 2.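

In the B1 bradykinin receptor assay, the aromatic 2-(methoxycarbonyl)phenyl group can stand in for the non-aromatic 2-(methoxycarbonyl)cyclohexyl group at a measurable but limited cost, a 5.0-fold higher number from compound 3 to compound 4 (0.70 log units; beyond the scatter), so this position accepts both kinds of six-membered carbon ring. In the B1 bradykinin receptor assay the large gap to the 2-(methoxycarbonyl)pyrrolidin-1-yl group therefore does not belong to the cyclohexyl group alone, an at least 450-fold lower number from compound 2 to compound 4 (2.65 log units; beyond the scatter), and that step starts from a limit of compound 2, not from a firm number: the limit of > 5000 nM in the B1 bradykinin receptor assay, at which 1 of the 4 values shown sits.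

In a physicochemical assay for lipophilicity (on this read-out higher numbers stand for higher lipophilicity and lower numbers for lower lipophilicity), compound 3 gives 2.7 and compound 4 gives 2.5, two values within the usual scatter of each other, so the two compounds cannot be told apart on this read-out.

Both compounds with firm low numbers carry the same methoxycarbonyl group in the same position, so the compounds shown do not tell how much of the result depends on that group or on where it sits on the ring. A carboxylic acid or an amide in place of the methyl ester on the phenyl ring would be needed to answer the first of these questions.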